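A few compounds are considered here, and "the series" means these few. Any claim that something is new, unique, unknown or untested is made for them only; others in the source may bear on it.

Compound 1 `O=C(c1ccc(F)c(F)c1)N1CC(c2nc(-c3cccc(F)c3)no2)C1` is an amide built on a shared core. Within the data shown here, in an assay on HEK293 cells for positive allosteric modulation of metabotropic glutamate receptor 5 (Homo sapiens), read by FLIPR (a lower number here means that less compound is needed, a higher number that more compound is needed for the effect), compound 1 gives 3200 nM, the single number among the two values shown. Compound 2 `Cc1ccc(S(=O)(=O)N2CC(c3nc(-c4cccc(Cl)c4)no3)C2)cc1`, a sulfonamide on the same core, reaches a limit of the assay rather than a number: in this assay compound 2 gives > 10000 nM. Compound 3 `O=C(C1CCC(F)(F)CC1)N1CC(c2nc(-c3cccc(F)c3)no2)C1` has not been measured; it differs from compound 1 by 4,4-difluorocyclohexyl in place of 3,4-difluorophenyl on a carbonyl carbon. Among the measured compounds shown here, no measured pair shows such a change, so the step of a 1.6-fold higher number from compound 1 to compound 3 (0.19 log units; within the scatter) is expected to be small, toward needing more compound, near the edge of the scatter. Compound 3 is expected at 5000 nM, between 1500 nM and 20000 nM.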

Compound 3, half-maximal effective concentration: 520 nM
Compound 3: the middle estimate sits 9.6-fold (0.98 log units) above what was measured; measured number outside the range, below it.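

Replacing the aromatic 3,4-difluorophenyl with the non-aromatic 4,4-difluorocyclohexyl on the carbonyl carbon keeps the same heavy atom count, yet gives a 6.2-fold lower number from compound 1 to compound 3 (0.79 log units; beyond the scatter) in this assay. Among these compounds, this is the first step between compounds differing in one place, and it shows that an aromatic ring is not needed here for the effect. The values shown do not explain why the number falls.

Going by these compounds, whether the two fluorines contribute remains open, as plain cyclohexyl would test that. Also open, on these data alone, is how a piperidine ring, which carries an amine, or an open chain such as isopropyl would behave on this carbonyl carbon.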